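Carbamate Arm to Benzoyl: an Expected Step in Cell Tolerance

The source may report more compounds than this note shows. Statements on the series, on what has been measured and on what is new or still open speak of the compounds shown alone.

Compound 1 `COc1ccc(N(CC(=O)NCCC[Te]c2ccccc2)C(=O)CNC(=O)OC(C)(C)C)cc1` carries on the shared core a ((tert-butoxycarbonyl)amino)methyl group attached to a carbonyl carbon. In a functional assay on SK-MEL-2 cells (Homo sapiens) for inhibition, with a stated time of 48 h (a higher number here means that more compound is tolerated, a lower number that less compound is tolerated), compound 1 gives only < 100000 nM, which is a limit of the assay and not a measured number. Two other compounds carry a different side arm: compound 2 `COc1ccc(N(CC(=O)NCCC[Te]c2ccccc2)C(=O)CCSC2=C(C)C(=O)c3ccccc3C2=O)cc1` gives 14800 nM in this assay, and compound 3 `CC1=C(SCCC(=O)OCC(=O)NCCC[Te]c2ccccc2)C(=O)c2ccccc2C1=O` gives 12900 nM. These two values lie within the usual scatter of each other. Compound 1 thus stands at the one limit among the three values, as shown by the limit of < 100000 nM in this assay, at which 1 of the 3 values shown sits; where it would fall as a number is not known.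

Compound 4 `COc1ccc(N(CC(=O)NCCC[Te]c2ccccc2)C(=O)c2ccccc2)cc1` has not been measured. Its change from compound 1 is phenyl in place of ((tert-butoxycarbonyl)amino)methyl on a carbonyl carbon. Among the measured compounds shown here, no measured pair of compounds shows the effect of this change, and compound 1 offers only a limit, so the size and direction of the step cannot be read from the data. The expected step is a step that the limit leaves unreadable from compound 1 to compound 4, given here as an estimate only. Compound 4 is expected to give about 40000 nM in this assay, within a range from 10000 nM to 100000 nM.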

Compound 4, concentration lethal to 50% of the cells: < 100000 nM
Compound 4: only a limit was reported (the forecaster's own chance of this, stated with the estimate: 30%); the middle value lies beyond the limit too.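

In this assay, among the compounds shown here, compound 1 and compound 4 are both reported only as a limit, so no step between them can be read: the limit of < 100000 nM in this assay, at which 2 of the 4 values shown sit. The compounds shown leave open where compound 1 and compound 4 would fall as numbers, and whether phenyl in place of ((tert-butoxycarbonyl)amino)methyl changes cell tolerance at all.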